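Trading an acid tail for a dimethylcarbamoyl ethenyl tail

A few compounds are considered here, and "the series" means these few. Any claim that something is new, unique, unknown or untested is made for them only; others in the source may bear on it.

Compound 1, `CNC(=O)/C=C/c1ccncc1-c1ccc2c(cnn2C)c1`, gives 3480 nM in a functional assay on HCT-116 cells (Homo sapiens) for inhibition, read by MTT assay, with a stated time of 72 h; on this read-out higher numbers stand for weaker inhibition of growth and lower numbers for stronger inhibition of growth.
Compound 2, `O=C(O)CCc1ccncc1-c1ccc2ccccc2c1`, gives only the limit > 30000 nM in this assay.
Compound 3, `O=C(CCc1ccncc1-c1ccc2ccccc2c1)N1CCOCC1`, gives only the limit > 30000 nM in this assay.

Compound 2 therefore stands at the edge of what this assay can report: its value is a limit, not a number, and the same holds for compound 3, so that two of the three values sit at the limit (the limit of > 30000 nM in this assay, at which 2 of the 3 values shown sit). Compound 4, `CN(C)C(=O)/C=C/c1ccncc1-c1ccc2ccccc2c1`, differs from compound 2 by 2-(dimethylcarbamoyl)ethenyl in place of 2-carboxyethyl on an aromatic carbon.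

Within the data shown here, only one measured step touches the same acid: the step that the two limits leave unreadable from compound 2 to compound 3, which cannot be read because both ends are limits. It gives no guide to the size or direction of the change in hand. The nearest measured relative of compound 4 is compound 1, sharing the ethenyl-linked amide though on a different core, and compound 1 does reach a number, 3480 nM. On that basis compound 4 is expected to move off the limit, with an estimated step of an at least 3.3-fold lower number from compound 2 to compound 4 (0.52 log units; beyond the scatter), though the chance of another limit remains real. The estimate for compound 4 is 9000 nM, between 2500 nM and 30000 nM.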

Compound 4, concentration for 50% growth inhibition: 4540 nM
Estimate against measurement, compound 4: 2.0-fold (0.30 log units) above; measured number inside the range.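

On the shared core, the position opposite the ring nitrogen now gives a change that can be read in this assay: an at least 6.6-fold lower number from compound 2 to compound 4 (0.82 log units; beyond the scatter). Until now both compounds on this core stood at a limit, so the earlier step from the acid to the morpholine amide could not be read, and nothing yet showed that a change in this tail could register in growth inhibition at all. Compound 4 is the only compound on this core with a number rather than a limit, which makes a single tail the whole of the readable evidence here, with the remaining values still at the edge of the assay: the limit of > 30000 nM in this assay, at which 2 of the 4 values shown sit.

The new tail differs from the old one in two ways at once, since the carboxylic acid gives way to a dimethyl amide and the saturated chain gives way to an ethenyl chain, so the step does not say which of the two carries the change. The pair that would separate them is 2-(dimethylcarbamoyl)ethyl, with the same amide on the saturated chain, and 2-carboxyethenyl, with the acid kept on the unsaturated chain.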